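Shortening the saturated chain on compound 2

A few compounds are considered here, and "the series" means these few. Any claim that something is new, unique, unknown or untested is made for them only; others in the source may bear on it.

The three measured compounds share one core and differ in the substituent attached to it. Compound 1 `CCCCCc1ccc(-c2cc3cn([C@H]4C[C@H](O)[C@@H](CO)O4)c(=O)nc3o2)cc1` carries a pentyl chain; in an ADME assay on HEL cells (Homo sapiens) for cytotoxicity, with a stated time of 3 days (a lower number here means that less compound is tolerated, a higher number that more compound is tolerated), compound 1 gives > 1300 nM, which is a limit of the assay and not a measured number. Compound 2 `CCCCCc1ccc(-c2cc3cn([C@H]4C[C@H](O)[C@@H](CO)O4)c(=O)nc3o2)nc1` carries the same pentyl chain on a different ring; in this assay compound 2 gives > 100000 nM, again a limit rather than a number. Compound 3 `O=c1nc2oc(C#Cc3ccccc3)cc2cn1[C@H]1C[C@H](O)[C@@H](CO)O1` carries an unsaturated linker to a further ring; in this assay compound 3 gives > 570000 nM, also only a limit. Since every value shown is a limit, no order among the three can be read, and compound 2 simply stands at the limit described by the limit of > 100000 nM in this assay, at which 1 of the 3 values shown sits, with the other two at the limit of > 1300 nM in this assay, at which 1 of the 3 values shown sits, and (the limit of > 570000 nM in this assay, at which 1 of the 3 values shown sits).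

Compound 4 `CCCCc1ccc(-c2cc3cn([C@H]4C[C@H](O)[C@@H](CO)O4)c(=O)nc3o2)nc1` differs from compound 2 by hydrogen in place of methyl on a saturated chain carbon, four bonds along the chain from an aromatic carbon. Going by the values given here, no measured pair shows such a change, so no step size can be taken from the data. Given that compound 2 sits at > 100000 nM, the expectation is that shortening the chain produces no step beyond the scatter, and the step of a number no higher from compound 2 to compound 4 (the limit leaves the size open) is estimated as essentially flat. Compound 4 is therefore expected to come out at about 100000 nM, within 30000 nM to 300000 nM, most likely again as a limit.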

Compound 4, minimum cytotoxic concentration: > 100000 nM
Compound 4: no number, only a limit; the forecaster's own chance of this, stated with the estimate: 80%; the middle value lies on the limit itself.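

In this assay compound 4 gives > 100000 nM, a limit of the assay and not a number. Going by these compounds alone, compound 2 also stands at a limit, so no step between compound 2 and compound 4 can be read. The compounds shown leave open whether hydrogen in place of methyl on this saturated chain carbon changes the minimum cytotoxic concentration at all.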